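The compounds below may be only part of what the source reports. "The series", "measured", "known", "first", "only" and "open" are said of these compounds alone.

Series notes, efficacy in a functional assay on HEK293 cells for agonist activity at D(4) dopamine receptor (Homo sapiens), read by FLIPR; on this read-out higher numbers stand for larger maximal responses and lower numbers for smaller maximal responses. Of the compounds shown here, two carry numbers so far. Compound 1 `COc1cccc(C)c1NC(=O)CN1CCC(c2cccc[n+]2[O-])CC1` gives 56% in this assay. Among the measured compounds shown here, compound 2 `O=C(CN1CCC(c2cccc[n+]2[O-])CC1)Nc1cccc(F)c1` gives 70% in this assay and stands highest of the two values, the gap to compound 1 being beyond the usual scatter of repeated runs; no single-point step between the two is on record, so only the two values themselves are compared here.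

The next compound, compound 3 `Cc1cccc(C)c1NC(=O)CN1CCC(c2cccc[n+]2[O-])CC1`, has not been run yet. Relative to compound 2 the change is 2,6-dimethylphenyl in place of 3-fluorophenyl on an amide-type nitrogen. For the measured compounds named here, no measured pair in the set reports what a change of this kind does to the maximal response; the only guide is that compound 1, which gives 56% and also carries a doubly substituted ring on the same amide-type nitrogen, sits well under compound 2.

On that basis the step from compound 2 to compound 3 is expected to be downward and roughly at the edge of the scatter, a number 12 percentage points lower from compound 2 to compound 3 (beyond the scatter). Compound 3 is therefore estimated at 58% in this assay, with a plausible range of 45% to 72%.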

Compound 3, largest response reached (reported as efficacy), in percent of the reference or control that the assay uses: 68%
The estimate for compound 3 lay 10 percentage points below the measured number, within the range that was stated.
By their numbers in this assay, from the lowest: compound 1; then compounds 3 and 2 (each within the scatter of the next).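

In this assay, 2,6-dimethylphenyl in place of 3-fluorophenyl on the amide-type nitrogen gives a number 2 percentage points lower from compound 2 to compound 3 (within the scatter), so this position accepts the doubly substituted ring with no change beyond the scatter, and such a ring as such cannot be tied to a lower maximal response. Methyl in place of methoxy on an aromatic carbon gives a number 12 percentage points higher from compound 1 to compound 3 (beyond the scatter), the first single-place comparison in the series to move the read-out beyond the scatter, and it ties the lower number of compound 1 to that one exchange on the ring rather than to the double substitution. No independent measurement in hand bears on why either step comes out as it does.

The compounds shown leave open how the maximal response follows the substituent on this ring when it is chlorine, an ethyl group or a nitrile, and whether a plain phenyl on the amide-type nitrogen would stay level with compound 2 and compound 3. They also leave open what a methyl group on the amide-type nitrogen, in place of the amide hydrogen, would do to the read-out.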